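The source may hold more compounds than are shown below. What is called first, only, known or untested is meant among the compounds shown, and "the series" means these compounds.

Compound 1, `COc1ccc(CNC(=O)/C=C/c2coc3cc(O)ccc3c2=O)cc1`, in a functional assay on L02 cells (Homo sapiens) for inhibition, read by MTT assay, with a stated time of 48 h; a lower number here means a stronger inhibitor, a higher number a weaker inhibitor: compound 1 reaches only the assay limit > 200000 nM.
Compound 2, `O=C(/C=C/c1coc2cc(O)ccc2c1=O)NCc1ccccc1`, in this assay: compound 2 likewise reaches only the limit > 200000 nM.
Compound 3, `COc1cccc(NC(=O)/C=C/c2coc3cc(OC)ccc3c2=O)c1`, in this assay: compound 3 also reaches only the limit > 200000 nM.

All three values shown for the shared core are limits, not numbers; they sit at the limit of > 200000 nM in this assay, at which 3 of the 3 values shown sit, so compound 3 stands no higher and no lower than any other compound here, and its true potency is simply not resolved. The next compound is compound 4, `CCOc1ccc(NC(=O)/C=C/c2coc3cc(OC)ccc3c2=O)cc1`. It differs from compound 3 by 4-ethoxyphenyl in place of 3-methoxyphenyl on an amide-type nitrogen. Among the measured compounds shown here, the only measured step that touches a change on an aromatic substituent is a step that the two limits leave unreadable from compound 1 to compound 2, and two limits leave its size unreadable. No readable step therefore bears on the move from compound 3 to compound 4, and no shift beyond the scatter can be expected in this assay in either direction; most likely compound 4 again ends at the limit. The expected step for compound 4 is a number no higher from compound 3 to compound 4 (the limit leaves the size open). Compound 4 is estimated at 200000 nM, within a range from 100000 nM to 400000 nM.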

Compound 4, half-maximal inhibitory concentration: > 200000 nM
Compound 4: a limit, no number; the forecaster's own chance of this, stated with the estimate: 85%; the middle value sits exactly at the limit.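

In this assay, among the compounds shown here, compound 4 gives > 200000 nM, which is a limit and not a number; compound 3 also reaches only a limit, so no step between compound 3 and compound 4 can be read. The compounds shown leave open how strongly each truly inhibits, and whether any change on the shared core alters that, with every value at the same place: the limit of > 200000 nM in this assay, at which 4 of the 4 values shown sit.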